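A few compounds are considered here, and "the series" means these few. Any claim that something is new, unique, unknown or untested is made for them only; others in the source may bear on it.

Going by the values given here, compound 3 `O=C(CSc1nnc(-c2ccncc2)o1)N/N=C/c1ccc(O)c(O)c1` gives 1260 nM in a functional assay on BGC-823 cells (Homo sapiens) for cytotoxicity, read by MTT assay, with a stated time of 48 h (a lower number here means a stronger inhibitor, a higher number a weaker inhibitor), the lowest of the three numbers measured so far. Compound 1 `O=C(CSc1nnc(-c2ccncc2)o1)N/N=C/c1ccc(Br)cc1` gives 24500 nM in this assay, and compound 2 `O=C(CSc1nnc(-c2ccncc2)o1)N/N=C/c1ccccc1F` gives 24000 nM. The step of a 1.0-fold lower number from compound 1 to compound 2 (0.01 log units; within the scatter) lies within the scatter, whereas a 19-fold lower number from compound 1 to compound 3 (1.29 log units; beyond the scatter) and a 19-fold lower number from compound 2 to compound 3 (1.28 log units; beyond the scatter) are large, so the dihydroxyphenyl group stands clearly apart from the two halogenated aryl groups.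

Compound 4 `COc1cc(/C=N/NC(=O)CSc2nnc(-c3ccncc3)o2)ccc1O` differs from compound 3 by methyl in place of hydrogen on an oxygen on an aromatic ring. Among the compounds with values here, no measured step touches a substituent on one of these oxygens: the two large steps replace the whole aryl group, so they bear on compound 4 only in showing that the dihydroxyphenyl set is where the low numbers sit. With one hydroxy kept and the other capped, a moderate rise is expected for compound 4, a 2.4-fold higher number from compound 3 to compound 4 (0.38 log units; beyond the scatter), though it may stay within the scatter. The estimate for compound 4 is therefore 3000 nM, in a range from 1000 nM to 10000 nM.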

Compound 4, half-maximal inhibitory concentration: 4320 nM
Compound 4: middle estimate off by 1.4-fold (0.16 log units), on the low side; the range from low to high includes it.
By their numbers in this assay, from the lowest: compound 3; then compound 4; then compounds 2 and 1 (each within the scatter of the next).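

In this assay the change of hydroxy to methoxy gives a 3.4-fold higher number from compound 3 to compound 4 (0.54 log units; beyond the scatter) and so shows that this oxygen is sensitive to capping, which the whole-ring replacements could not show. The 4-hydroxy-3-methoxyphenyl group nevertheless keeps compound 4 clear of the halogenated aryl compounds, with a 5.6-fold lower number from compound 2 to compound 4 (0.74 log units; beyond the scatter) and a 5.7-fold lower number from compound 1 to compound 4 (0.75 log units; beyond the scatter) in this set, so among these four compounds the low numbers do not belong to the 3,4-dihydroxyphenyl group alone. No measurement at hand accounts for the rise on adding the methyl.

The compounds shown leave open whether capping the other hydroxy would give a step of the same size. They also leave open how an ethoxy group, an amine or a carboxylic acid would fare at this place on the ring.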